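Cytotoxicity notes: vinyl to bromo on the aromatic ring

The source may hold more compounds than are shown below. What is called first, only, known or untested is meant among the compounds shown, and "the series" means these compounds.

Compound 1 `C=CCNC(=O)[C@@H](NC(=O)[C@](O)(CCCN(Cc1ccc(Br)cc1)NC(=O)[C@@H](NC(=O)OC)C(C)(C)C)Cc1ccc(Br)cc1)C(C)C`: 4500 nM
Compound 2 `C=CCNC(=O)[C@@H](NC(=O)[C@@](O)(CCCN(Cc1ccc(Br)cc1)NC(=O)[C@@H](NC(=O)OC)C(C)(C)C)Cc1ccc(Br)cc1)C(C)(C)C`: 29000 nM
Compound 3 `C=CCNC(=O)[C@@H](NC(=O)[C@](O)(CCCN(Cc1ccc(Br)cc1)NC(=O)[C@@H](NC(=O)OC)C(C)(C)C)Cc1ccc(C=C)cc1)C(C)(C)C`: 25000 nM

All three values come from an ADME assay on MT4 cells (Homo sapiens) for cytotoxicity, read by XTT assay, with a stated time of 5 days; a higher number here means that more compound is tolerated, a lower number that less compound is tolerated. Compound 3 gives 25000 nM, which lies within the scatter of compound 2 at 29000 nM. Compound 1 gives 4500 nM, a lower number than that of compound 3, and the gap lies beyond the scatter.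

Next in line is compound 4 `C=CCNC(=O)[C@@H](NC(=O)[C@](O)(CCCN(Cc1ccc(Br)cc1)NC(=O)[C@@H](NC(=O)OC)C(C)(C)C)Cc1ccc(Br)cc1)C(C)(C)C`, still unmeasured. Its difference from compound 3 is bromo in place of vinyl on an aromatic carbon, para to a large group (bromo in place of vinyl on an aromatic carbon). For the measured compounds named here, no measured pair in this set shows a step of this kind, so the data offer no direct guide to its size or direction. The expectation therefore rests on compound 3 at 25000 nM as the starting point, and no shift beyond the scatter is expected in this assay. The expected change is a 1.1-fold lower number from compound 3 to compound 4 (0.06 log units; within the scatter), which stays within the scatter. The range is kept wide on the low side, since compound 1 at 4500 nM shows that much lower numbers occur among these compounds. For compound 4 the estimated value is 22000 nM, with an expected range of 10000 nM to 40000 nM.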

Compound 4, half-maximal cytotoxic concentration: 21000 nM
For compound 4 the middle estimate is 1.0-fold (0.02 log units) above the measured one, and the stated range covers the measured number.
By their numbers in this assay, from the lowest: compound 1; then compounds 4, 3 and 2 (each within the scatter of the next).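

In this assay, bromo in place of vinyl on an aromatic carbon, para to a large group, gives a 1.2-fold lower number from compound 3 to compound 4 (0.08 log units; within the scatter), so this assay does not separate the 4-vinylbenzyl and 4-bromobenzyl forms in this pair. The drawn configuration at the saturated chain carbon also gives a step within the scatter, a 1.4-fold lower number from compound 2 to compound 4 (0.14 log units; within the scatter), and this pair reads configuration alone, with no change of group: the fact that compounds 2 and 4 differ only in the configuration as drawn. For the compounds shown here, the only new step beyond the scatter lies at a different place, a saturated chain carbon bound to three saturated chain carbons, where methyl in place of hydrogen gives a 4.7-fold higher number from compound 1 to compound 4 (0.67 log units; beyond the scatter), a modest step resting on this single pair.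

Still open is whether the number stays in the same range with an amine, a carboxylic acid or a nitrile on that aromatic carbon, since vinyl and bromo are the only groups shown there. Also open, from the compounds shown here alone, is whether a longer chain at the saturated chain carbon extends the step seen with methyl, and whether that step holds with the other drawn configuration.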